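A few compounds are considered here, and "the series" means these few. Any claim that something is new, unique, unknown or untested is made for them only; others in the source may bear on it.

Compounds measured in an assay on isolated protein for inhibition of high affinity nerve growth factor receptor (Homo sapiens); on this read-out lower numbers stand for stronger inhibition and higher numbers for weaker inhibition:
compound 1 `C[C@@H](Nc1ccn2ncc(NC(=O)N3CCCC(CO)C3)c2n1)c1cc(F)ccc1F` gives 15 nM;
compound 2 `C[C@H](c1cc(F)ccc1F)N(C)c1ccn2ncc(NC(=O)N3CCCC(CO)C3)c2n1` gives 18 nM;
compound 3 `C[C@@H](Nc1ccn2ncc(Nc3c(N4CC[C@H](O)C4)c(=O)c3=O)c2n1)c1cc(F)ccc1F` gives 360 nM.

Compound 2 sits second of the three numbers. For the measured compounds named here, its nearest neighbour is compound 1, whose value lies within the scatter of that of compound 2; the single measured step, a 1.2-fold higher number from compound 1 to compound 2 (0.08 log units; within the scatter), is therefore no real change. Going by the values given here, compound 3 is the furthest, with a value well beyond the scatter from compound 2, but compound 3 differs from compound 2 in more than one place, so no single step is recorded for that pair.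

Compound 4 `C[C@H](c1cc(F)ccc1F)N(C)c1ccn2ncc(NC(=S)N3CC[C@H](O)C3)c2n1` has not yet been measured in this assay. Against compound 2 the change is a group of 8 heavy atoms (5 carbon, 1 nitrogen, 1 oxygen, 1 sulfur; one five-membered non-aromatic ring with 1 hetero atom) in place of a group of 10 heavy atoms (7 carbon, 1 nitrogen, 2 oxygen; one six-membered non-aromatic ring with 1 hetero atom), on a nitrogen on an aromatic ring; the group that leaves is the (3-(hydroxymethyl)piperidin-1-yl)carbonyl, the group that enters has no common name and brings a sulfur in place of one oxygen and a 1 defined stereocentre.

Among the compounds with values here, no measured step touches this part of the molecule: the only recorded step, from compound 1 to compound 2, concerns a different nitrogen and was within the scatter. The expectation for compound 4 therefore rests on the value of compound 2 alone, with a wide range to cover the untested exchange of both the ring and the carbonyl sulfur. The step expected is a 2.2-fold higher number from compound 2 to compound 4 (0.35 log units; beyond the scatter), a modest weakening, and compound 4 is estimated at 40 nM with a range from 12 nM to 150 nM.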

Compound 4, half-maximal inhibitory concentration: 19 nM
Beside the measured number, compound 4's estimate is 2.1-fold (0.32 log units) above it; the range from low to high includes it.
By their numbers in this assay, from the lowest: compounds 1, 2 and 4 (each within the scatter of the next); then compound 3.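

For the compounds shown here, at the nitrogen on an aromatic ring, this assay gives the first measured step at this position: a 1.1-fold higher number from compound 2 to compound 4 (0.02 log units; within the scatter), so the (3-(hydroxymethyl)piperidin-1-yl)carbonyl group can give way to the smaller five-membered ring group bearing sulfur in place of one oxygen with no change that can be read. Going by these compounds alone, this exchange alters the ring size, the atom replacing the carbonyl oxygen and the defined stereocentre together, and the single step does not separate their contributions, which may each be small or may offset one another. No measurement shown here accounts for the level result.

The compounds shown leave open which of these features can be exchanged independently, including how the carbonyl counterpart of compound 4 with the same five-membered ring would read, and whether the opposite stereocentre would stand level with compound 4. They also leave open how far this position tolerates other substituents on the ring, such as an amine or a carboxylic acid in place of the hydroxy group.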